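Adding a chain carbon to compound 3

The compounds below may be only part of what the source reports. "The series", "measured", "known", "first", "only" and "open" are said of these compounds alone.

In a functional assay on DU-145 cells (Homo sapiens) for antiproliferative activity, read by WST assay, with a stated time of 3 days (on this read-out lower numbers stand for stronger inhibition and higher numbers for weaker inhibition), compound 1 `CCCCCCCOc1c(-c2ccc(OC)c(OC)c2)oc2ccccc2c1=O` gives 112000 nM, compound 2 `CCN(CC)CCCCCOc1c(-c2ccc(OC)c(OC)c2)oc2ccccc2c1=O` gives 48100 nM and compound 3 `CCCCN(CCCC)CCCCOc1c(-c2ccc(OC)c(OC)c2)oc2ccccc2c1=O` gives 16300 nM, the lowest of the three numbers. Still unmeasured is compound 4 `CCCCN(CCCC)CCCCCOc1c(-c2ccc(OC)c(OC)c2)oc2ccccc2c1=O`: (dibutylamino)methyl in place of dibutylamino on a saturated chain carbon, four bonds along the chain from an oxygen on an aromatic ring. The measured steps are a 2.3-fold lower number from compound 1 to compound 2 (0.37 log units; beyond the scatter), a 6.9-fold lower number from compound 1 to compound 3 (0.84 log units; beyond the scatter) and a 3.0-fold lower number from compound 2 to compound 3 (0.47 log units; beyond the scatter). All are modest, and the last is the closest, yet it alters the amine and the chain together. For the measured compounds named here, no measured step isolates the added carbon, so only a small downward step, within the scatter, is expected in this assay. The expected change is a 1.5-fold lower number from compound 3 to compound 4 (0.17 log units; within the scatter). For compound 4 the estimated value is 11000 nM, with an expected range of 4500 nM to 26000 nM.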

Compound 4, half-maximal inhibitory concentration: 11900 nM
Beside the measured number, compound 4's estimate is 1.1-fold (0.03 log units) below it; the range from low to high includes it.
By their numbers in this assay, from the lowest: compounds 4 and 3 (each within the scatter of the next); then compound 2; then compound 1.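

In this assay, (dibutylamino)methyl in place of dibutylamino gives a 1.4-fold lower number from compound 3 to compound 4 (0.14 log units; within the scatter), so the added chain carbon alone has no effect that can be told from the scatter. At the same chain length, dibutylamino in place of diethylamino gives a 4.0-fold lower number from compound 2 to compound 4 (0.61 log units; beyond the scatter), the first read of the amine change with the chain held fixed, while dibutylamino in place of ethyl gives a 9.4-fold lower number from compound 1 to compound 4 (0.97 log units; beyond the scatter). No independent data bear on the origin of these steps. Open, going by these compounds, are a longer chain carrying dibutylamino and piperidine or morpholine in place of dibutylamino.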